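Methyl for hydrogen on the phenyl ring of a pyrazole sulfone

The source may report more compounds than this note shows. Statements on the series, on what has been measured and on what is new or still open speak of the compounds shown alone.

Measured so far:
compound 1 `O=S(=O)(CC1=NCCO1)c1n[nH]cc1-c1ccccc1` — 53.3%
compound 2 `O=S(=O)(CC1=NCCS1)c1n[nH]cc1-c1ccccc1` — "not active" (no number reported)

Among the measured compounds shown here, compound 1 is the only member of this small set with a reported number. In a functional assay, tested at 50 ug/mL (a lower number here means a weaker effect, a higher number a stronger effect of the compound at the concentration tested), compound 1 gives 53.3%. Compound 2, which carries a sulfur in place of the oxygen of the five-membered ring attached through the sulfone, is reported in this assay as "not active" (no number reported), and no number was given for it, so nothing can be said about the size of the gap between the two beyond the fact that compound 1 shows a measurable effect and compound 2 does not.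

Compound 3 `Cc1ccc(-c2c[nH]nc2S(=O)(=O)CC2=NCCO2)cc1` has not yet been measured. It differs from compound 1 in one place: methyl in place of hydrogen on an aromatic carbon. The core and the sulfone-linked five-membered ring are unchanged, and only the outer edge of the phenyl ring is altered.

With no measured step of this kind in the set, the expectation rests on the single number of compound 1 alone. Compound 3 is expected to give about 50% in this assay, within roughly 25% to 75%, which means an expected step of a number 3.3 percentage points lower from compound 1 to compound 3 (within the scatter) that stays within the scatter of the measurement, neither clearly stronger nor clearly weaker than compound 1.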

Compound 3, a percentage reported as activity, at one concentration (the size of the read-out at that concentration, not a potency): 60.7%
For compound 3 the middle estimate is 10.7 percentage points below the measured one, within the range that was stated.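

In this assay, methyl in place of hydrogen on the phenyl ring, para to a large group, gives a number 7.4 percentage points higher from compound 1 to compound 3 (within the scatter), so the two compounds cannot be told apart at the concentration tested. Among the compounds shown here, the earlier pair showed only what happens when the sulfone-linked five-membered ring is altered, with the effect lost in compound 2; this step is the first look at the outer edge of the phenyl ring, and there the added carbon leaves a clear read-out in place. No measurement shown here bears on why the phenyl to 4-methylphenyl change leaves the read-out within the scatter.

As far as these compounds go, a single small group at one place on the ring says little about how far this tolerance reaches, so it stays open whether a longer chain, a methoxy group, a chlorine, an amine or a carboxylic acid at the same place would keep the effect. Also open, from the compounds shown here alone, is whether methyl would be accepted elsewhere on the phenyl ring, and whether compound 3 and compound 1 would still match at other concentrations, since one concentration gives the size of the effect and not a potency.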